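A Smaller Group on the Nitrogen of Compound 3

The compounds below may be only part of what the source reports. "The series", "measured", "known", "first", "only" and "open" are said of these compounds alone.

Of the compounds shown here, three sharing one core have been measured in a functional assay on RKOp27 cells (Homo sapiens) for cytotoxicity, read by MTT assay, with a stated time of 3 days; a lower number here means a stronger inhibitor, a higher number a weaker inhibitor. Compound 1 `N#Cc1c(O)nc(SCc2nc3ccccc3[nH]2)nc1-c1ccccc1` gives 6.09 nM, compound 2 `CNc1nc(SCc2nc3ccccc3[nH]2)nc(-c2ccccc2)c1C#N` gives 3.7 nM, and compound 3 `N#Cc1c(Nc2nccs2)nc(SCc2nc3ccccc3[nH]2)nc1-c1ccccc1` gives 3.2 nM. These values all lie within the usual scatter of one another, so compound 3 stands level with the other two.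

Compound 4 `N#Cc1c(NC(N)=S)nc(SCc2nc3ccccc3[nH]2)nc1-c1ccccc1` differs from compound 3 in one place: a group of 3 heavy atoms (1 carbon, 1 nitrogen, 1 sulfur; no ring) in place of a group of 5 heavy atoms (3 carbon, 1 nitrogen, 1 sulfur; one five-membered aromatic ring with 2 hetero atoms), on a nitrogen on an aromatic ring. The closest evidence is the exchange of methyl for 1,3-thiazol-2-yl on that same nitrogen, a 1.2-fold lower number from compound 2 to compound 3 (0.06 log units; within the scatter). Two other exchanges at the same place on the core, a 1.6-fold lower number from compound 1 to compound 2 (0.22 log units; within the scatter) and a 1.9-fold lower number from compound 1 to compound 3 (0.28 log units; within the scatter), were also small. The group entering in compound 4 has not been measured on this core, so this comparison remains indirect. No step beyond the scatter is therefore expected in this assay. The estimated change is a 1.3-fold higher number from compound 3 to compound 4 (0.10 log units; within the scatter). Compound 4 is expected at about 4 nM, with an estimated range of 1.8 nM to 9 nM.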

Compound 4, half-maximal inhibitory concentration: 2.63 nM
The estimate for compound 4 lay 1.5-fold (0.18 log units) above the measured number; the measured number falls inside the stated range.
By their numbers in this assay, from the lowest: compounds 4, 3, 2 and 1 (each within the scatter of the next, the first and the last beyond it).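

In this assay the group entering in compound 4 has no ring, yet its number stays level with that of the thiazole-bearing compound (a 1.2-fold lower number from compound 3 to compound 4 (0.09 log units; within the scatter)) and with that of the methyl-bearing compound (a 1.4-fold lower number from compound 2 to compound 4 (0.15 log units; within the scatter)), so a ring on this nitrogen is not required for a low number among these compounds. For the compounds shown here, compound 4 also gives the first step beyond the scatter at this place on the core, though only a modest one (a 2.3-fold lower number from compound 1 to compound 4 (0.36 log units; beyond the scatter)), while it stays within the scatter of compounds 2 and 3. Nothing available explains these small differences.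

Still open, on these data alone, is whether a plain amino group or a longer chain, such as hexyl, on this nitrogen would stay at the same level. Whether a carboxylic acid at this place would do so is equally unsettled.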